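The source may report more compounds than this note shows. Statements on the series, on what has been measured and on what is new or still open speak of the compounds shown alone.

Measured compounds:

Compound 1 `CCCNc1nc(=O)c2cc(C(F)(F)F)cc([N+](=O)[O-])c2s1` — in an ADME assay on Vero cells (Chlorocebus sabaeus) for cytotoxicity, read by MTT assay, with a stated time of 72 h (on this read-out higher numbers stand for weaker inhibition and lower numbers for stronger inhibition), compound 1 gives > 100000 nM, a limit of the assay and not a number.
Compound 2 `O=c1nc(N2CCCCC2)sc2c([N+](=O)[O-])cc(C(F)(F)F)cc12` — in this assay compound 2 gives > 100000 nM, again a limit of the assay rather than a number.

Compound 2 therefore stands only at a limit; both values shown sit at the limit of > 100000 nM in this assay, at which 2 of the 2 values shown sit, and the step that the two limits leave unreadable from compound 1 to compound 2 cannot be sized from two limits.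

Compound 3 `O=C(O)C1CCN(c2nc(=O)c3cc(C(F)(F)F)cc([N+](=O)[O-])c3s2)CC1` differs from compound 2 by carboxy in place of hydrogen on a saturated ring carbon. For the measured compounds named here, the only measured step, a step that the two limits leave unreadable from compound 1 to compound 2, alters the same ring nitrogen substituent and is unreadable, so it gives no direction for a change on a saturated ring carbon of that piperidine. With both neighbouring values at the limit, no step beyond the scatter can be argued for in this assay in either direction; the expectation is that compound 3 also reaches no readable value.

The estimate for compound 3 in this assay is 200000 nM, within 60000 nM to 800000 nM, which corresponds to an expected step that the limit leaves unreadable from compound 2 to compound 3, most probably reported again only as a limit.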

Compound 3, half-maximal inhibitory concentration: > 100000 nM
Compound 3: a limit, no number (the forecaster's own chance of this, stated with the estimate: 85%); the middle value is on the limit's open side.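

In this assay compound 3 gives > 100000 nM, a limit of the assay and not a number. No step from compound 1 or compound 2 to compound 3 can be read, because all three compounds share one limit: the limit of > 100000 nM in this assay, at which 3 of the 3 values shown sit.

Left open is how compound 1, compound 2 and compound 3 rank in this assay, and whether any change on the shared core gives a readable value.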